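The compounds below may be only part of what the source reports. "The series", "measured", "known", "first", "only" and "open" are said of these compounds alone.

Measured compounds:
compound 1 `COc1ccc(F)c(-c2ccc3c(NC(=O)c4ccc(N(C)CCN(C)C)cc4)n[nH]c3c2)c1F` — 333 nM
compound 2 `COc1cccc(-c2ccc3c(NC(=O)c4ccc(N5CCN(C)CC5)cc4F)n[nH]c3c2)c1F` — > 1000 nM (a limit)
compound 3 `COc1cccc(-c2ccc3c(NC(=O)c4ccc(N5CCN(C)CC5)c(F)c4)n[nH]c3c2)c1F` — > 1000 nM (a limit)

Among the compounds with values here, in a functional assay on KG-1 cells (Homo sapiens) for antiproliferative activity, read by CCK-8 assay, with a stated time of 72 h (a higher number here means a weaker inhibitor, a lower number a stronger inhibitor), compound 1 gives 333 nM, the only numerical value in the set. Compound 2 reports a limit, > 1000 nM. Compound 3 likewise reports a limit, > 1000 nM. Within the data shown here, two of the three values therefore sit at the limit of > 1000 nM in this assay, at which 2 of the 3 values shown sit, and no step between measured compounds that differ in one place is available.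

Compound 4 `COc1ccc(F)c(-c2ccc3c(NC(=O)c4ccc(N5C[C@@H](C)N[C@@H](C)C5)cc4)n[nH]c3c2)c1F` differs from compound 1 by 3,5-dimethylpiperazin-1-yl in place of (2-(dimethylamino)ethyl)(methyl)amino on an aromatic carbon. Among the measured compounds shown here, with no measured precedent, the step from compound 1 to compound 4 is expected to be small, a 1.5-fold higher number from compound 1 to compound 4 (0.18 log units; within the scatter), at most modestly toward weaker inhibition. Compound 4 is estimated at 500 nM, within 150 nM to 2000 nM.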

Compound 4, half-maximal inhibitory concentration: 348 nM
Compound 4: middle estimate off by 1.4-fold (0.16 log units), on the high side; the range from low to high includes it.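

On the aromatic carbon para to a large group, in this assay, the open chain and the ring read alike, with a 1.0-fold higher number from compound 1 to compound 4 (0.02 log units; within the scatter). Within the data shown here, this is the only step between compounds differing in one place, and it shows that this position accepts 3,5-dimethylpiperazin-1-yl, with its 2 defined stereocentres and 1 hydrogen-bond donor, without a difference beyond the scatter. Nothing measured here gives a cause for this result.

Going by these compounds, whether a morpholine or an unsubstituted piperazine at this position would read the same remains open. So does the effect of a longer aminoalkyl chain.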